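Replacing an Ester Side Chain with Propargyl

The compounds below may be only part of what the source reports. "The series", "measured", "known", "first", "only" and "open" are said of these compounds alone.

In a functional assay on HL-60 cells (Homo sapiens) for cytotoxicity, read by MTT assay, with a stated time of 24 h (on this read-out higher numbers stand for weaker inhibition and lower numbers for stronger inhibition), compound 1 `CN1CCN(CCCCCOc2c(Br)cc(Br)cc2Oc2ccc(Br)cc2Br)CC1` gives 48.3 ug/mL and compound 2 `CCOC(=O)C(C)Oc1c(Br)cc(Br)cc1Oc1ccc(Br)cc1Br` gives 35.7 ug/mL so these two numbers lie within the usual scatter of each other, and compound 2 cannot be ranked against compound 1. Compound 3 `C#CCOc1c(Br)cc(Br)cc1Oc1ccc(Br)cc1Br` keeps the shared core and carries propargyl in place of 1-(ethoxycarbonyl)ethyl on an oxygen on an aromatic ring. Going by the values given here, no measured pair differs in just one place, so nothing shows directly what such a swap does. The side chains of compound 1 and compound 2 look very different, yet their numbers stay within the scatter. The expectation is therefore no move beyond the scatter, with an estimated 1.1-fold lower number from compound 2 to compound 3 (0.03 log units; within the scatter) of small size. For compound 3 the estimated value is 33 ug/mL with an expected range from 14 ug/mL to 75 ug/mL on this uncertain footing.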

Compound 3, half-maximal inhibitory concentration: 29.7 ug/mL
For compound 3 the middle estimate is 1.1-fold (0.05 log units) above the measured one; the measured number falls inside the stated range.
By their numbers in this assay, from the lowest: compounds 3, 2 and 1 (each within the scatter of the next).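

Going by these compounds alone, compound 2 and compound 3 form the first pair that differs in one place only, so they give a direct reading of a swap on an oxygen on an aromatic ring: this assay shows a 1.2-fold lower number from compound 2 to compound 3 (0.08 log units; within the scatter) for this change. Here propargyl, with 3 heavy atoms and 0 hydrogen-bond acceptors, replaces 1-(ethoxycarbonyl)ethyl, with 7 heavy atoms and 2 hydrogen-bond acceptors, and the number stays within the scatter, so in this pair the larger side chain is not needed to keep the read-out. Nothing available explains why the number holds. On these data alone, it remains open whether an amine or a carboxylic acid on this oxygen would move the number beyond the scatter. As far as these compounds go, it is equally open whether a longer chain ending in a triple bond would match propargyl.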